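The source may report more compounds than this note shows. Statements on the series, on what has been measured and on what is new or still open speak of the compounds shown alone.

Of the two numbers shown in an assay on CHO cells for positive allosteric modulation of metabotropic glutamate receptor 5 (Homo sapiens), read by FLIPR (on this read-out lower numbers stand for an effect already at smaller amounts and higher numbers for an effect only at larger amounts of compound), compound 2 `O=C(Nc1ccc(Cl)cc1CN1C(=O)c2ccccc2C1=O)C1CCCCC1` stands lowest with 1500 nM. Compound 3 `CCN(Cc1cc(Cl)ccc1NC(=O)c1ccccn1)C(=O)c1cc(Cl)cc(Cl)c1` gives 470000 nM in this assay, a gap beyond the scatter. Compound 1 `COc1ccc2c(c1OC)C(=O)N(Cc1cc(Br)ccc1NC(=O)c1ccccn1)C2=O` reaches only a limit of this assay, > 100000 nM; this is the limit of > 100000 nM in this assay, at which 1 of the 3 values shown sits. Compound 4 `O=C(Nc1ccc(Cl)cc1CN1C(=O)c2ccccc2C1=O)c1cncs1` is not yet measured. It differs from compound 2 in one place: 1,3-thiazol-5-yl in place of cyclohexyl on a carbonyl carbon. Among the measured compounds shown here, no measured step in this assay resolves this change on its own, since compounds 1 and 3 also differ elsewhere. A small loss, about the edge of the scatter, is expected for the step of a 2.0-fold higher number from compound 2 to compound 4 (0.30 log units; within the scatter). Compound 4 is therefore estimated at 3000 nM in this assay, within 800 nM to 15000 nM.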

Compound 4, half-maximal effective concentration: 1900 nM
The estimate for compound 4 lay 1.6-fold (0.20 log units) above the measured number; measured number inside the range.
By their numbers in this assay, from the lowest: compounds 2 and 4 (each within the scatter of the next); then compound 3.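

In this assay, 1,3-thiazol-5-yl replaces cyclohexyl on the carbonyl carbon with a 1.3-fold higher number from compound 2 to compound 4 (0.10 log units; within the scatter). This is the only single-place comparison shown, and it indicates that this position accepts a five-membered aromatic ring with 2 hetero atoms as well as a six-membered non-aromatic carbon ring, without a change beyond the scatter. No measurement shown bears on a cause for this step.

Open, on these data alone, is whether this position also accepts an open-chain group such as n-butyl, or a ring carrying a primary amine or a carboxylic acid.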